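The source may report more compounds than this note shows. Statements on the series, on what has been measured and on what is new or still open speak of the compounds shown alone.

Measured so far:
- compound 1 `CCCC(CC)C(=O)Nc1ccc2c(c1)c(Cc1ccc(C(=O)O)cc1OC)cn2C`: in an assay on lung parenchyma for displacement of a labelled ligand from cysteinyl leukotriene receptor 1 (Cavia porcellus) (a lower number here means a stronger inhibitor, a higher number a weaker inhibitor), compound 1 gives 1830 nM
- compound 2 `COc1cc(C(=O)O)ccc1Cc1c[nH]c2ccc(NC(=O)OC3CCCC3)cc12`: in this assay compound 2 gives 236 nM

Compound 2 holds the lowest number of the two; its nearest neighbour is compound 1, whose number is higher by a gap well beyond the scatter. The two share the core of compound 2 but differ in more than one place, so their values show only that much.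

The step under consideration leads to compound 3 `COc1cc(C(=O)O)ccc1Cc1cn(C)c2ccc(NC(=O)OC3CCCC3)cc12`, which is compound 2 changed in one place: methyl in place of hydrogen on an aromatic nitrogen. Compound 1 also carries a methyl on that aromatic nitrogen, but its other difference from compound 2 leaves the weight of this change open. Within the data shown here, no step between measured compounds isolates it, so only a moderate shift towards a higher number is expected in this assay for the step of a 2.3-fold higher number from compound 2 to compound 3 (0.37 log units; beyond the scatter). For compound 3 the estimate is 550 nM, with a range from 150 nM to 2000 nM.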

Compound 3, inhibition constant: 157 nM
Compound 3: the middle estimate sits 3.5-fold (0.54 log units) above what was measured; the measured number falls inside the stated range.
By their numbers in this assay, from the lowest: compounds 3 and 2 (each within the scatter of the next); then compound 1.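

In this assay, methyl in place of hydrogen on an aromatic nitrogen gives a 1.5-fold lower number from compound 2 to compound 3 (0.18 log units; within the scatter) and so leaves compound 2 and compound 3 level, which means a free hydrogen on that nitrogen is not required for this read-out. With the methyl present in both compounds, cyclopentyloxy in place of 1-ethylbutyl on a carbonyl carbon gives a 12-fold lower number from compound 1 to compound 3 (1.07 log units; beyond the scatter) as a large step, so that change, not the methyl, accounts for the separation of compound 1 from the other two compounds. No measurement here bears on why either step has the size it has.

On these data alone, whether ethyl or benzyl on the aromatic nitrogen would stay level with compound 2 and compound 3 remains open. So does how cyclohexyloxy or a longer chain on the carbonyl carbon would compare with cyclopentyloxy.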